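Notes on a methoxyphenyl to ethoxyphenyl exchange

A few compounds are considered here, and "the series" means these few. Any claim that something is new, unique, unknown or untested is made for them only; others in the source may bear on it.

Measured so far:
Compound 1 `COc1ccccc1-n1nncc1CN1C(=O)C2(C(C#N)=C(N)Oc3c2c2nc4ccccc4nc2c2ccccc32)c2ccccc21` in a functional assay on MCF7 cells (Homo sapiens) for antiproliferative activity, read by MTT assay, with a stated time of 48 h (a higher number here means a weaker inhibitor, a lower number a stronger inhibitor), gives > 50000 nM, which is a limit of the assay and not a number.
Compound 2 `CCOc1ccc(-n2nncc2CN2C(=O)C3(C(C#N)=C(N)Oc4c3c3nc5ccccc5nc3c3ccccc43)c3ccccc32)cc1` in this assay gives > 50000 nM, likewise a limit.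
Compound 3 `COc1ccccc1-n1nncc1CN1C(=O)C2(C(C#N)=C(N)Oc3c(N)cc4nc5ccccc5nc4c32)c2ccccc21` in this assay gives 28900 nM.

Compound 1 and compound 2 differ by 4-ethoxyphenyl in place of 2-methoxyphenyl on an aromatic nitrogen. The step that the two limits leave unreadable from compound 1 to compound 2 cannot be read, since both values sit at the limit of > 50000 nM in this assay, at which 2 of the 3 values shown sit. Compound 3 carries another core; the difference between the two cores is not broken down here. Compound 4 `CCOc1ccc(-n2nncc2CN2C(=O)C3(C(C#N)=C(N)Oc4c(N)cc5nc6ccccc6nc5c43)c3ccccc32)cc1`, not yet measured, stands to compound 3 as 4-ethoxyphenyl in place of 2-methoxyphenyl on an aromatic nitrogen, the same change at the same place as that from compound 1 to compound 2. The earlier step gives no readable size, so the expectation rests on compound 3 alone. The expected step of a 1.2-fold higher number from compound 3 to compound 4 (0.08 log units; within the scatter) is small, within the usual scatter, with a fair chance that only a limit is reported. For compound 4 the estimate is 35000 nM, between 14000 nM and 90000 nM, resting on compound 3 giving 28900 nM.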

Compound 4, half-maximal inhibitory concentration: 26800 nM
The estimate for compound 4 lay 1.3-fold (0.12 log units) above the measured number, and the stated range covers the measured number.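

In this assay, 4-ethoxyphenyl in place of 2-methoxyphenyl gives a 1.1-fold lower number from compound 3 to compound 4 (0.03 log units; within the scatter), so on the core of compound 3 the two groups cannot be told apart. Compound 1 and compound 2 each stand at a limit of the assay and not at a number, so the same change on that core cannot be read and no carry-over between cores is shown: the limit of > 50000 nM in this assay, at which 2 of the 4 values shown sit.

Among the compounds shown here, the finding therefore rests on one readable pair and gives no size for the step on the other core.

Open, from the compounds shown here alone, is what a phenyl group bearing an amine or a carboxylic acid, or a chain longer than ethoxy, would give on the core of compound 3. The exchange also alters the chain and its place on the phenyl ring together, and these two stay unseparated.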